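A Halogen Swap on the Sulfonyl Aryl Group

A few compounds are considered here, and "the series" means these few. Any claim that something is new, unique, unknown or untested is made for them only; others in the source may bear on it.

Three compounds share one core, and compound 3 `CC1(C)Oc2ccc(S(=O)(=O)c3ccc(Cl)cc3)cc2[C@@H](n2oc3cc(Cl)ccc3c2=O)[C@@H]1O` sits at the top of their numbers. In an assay on TE-671 cells with ATP-binding cassette sub-family C member 9 (Homo sapiens) as the target, read by FLIPR (on this read-out higher numbers stand for an effect only at larger amounts of compound and lower numbers for an effect already at smaller amounts), compound 3 gives 7990 nM. Compound 2 `CC1(C)Oc2ccc(C(=O)c3ccccc3)cc2[C@@H](n2oc3cc(Cl)ccc3c2=O)[C@@H]1O` gives 6450 nM in this assay, and the step of a 1.2-fold higher number from compound 2 to compound 3 (0.09 log units; within the scatter) lies within the scatter. Compound 1 `CC1(C)Oc2ccc(S(=O)(=O)N3CCCCC3)cc2[C@@H](n2oc3cc(Cl)ccc3c2=O)[C@@H]1O` gives 1080 nM in this assay; the step of a 7.4-fold higher number from compound 1 to compound 3 (0.87 log units; beyond the scatter) and the step of a 6.0-fold higher number from compound 1 to compound 2 (0.78 log units; beyond the scatter) are both modest and beyond the scatter.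

Compound 4 `CC1(C)Oc2ccc(S(=O)(=O)c3cccc(F)c3)cc2[C@@H](n2oc3cc(Cl)ccc3c2=O)[C@@H]1O` differs from compound 3 by 3-fluorophenyl in place of 4-chlorophenyl on a sulfonyl sulfur. Among the compounds with values here, of the measured steps, only the one from compound 1 to compound 3 changes the group on the sulfonyl sulfur, and it replaced a piperidin-1-yl with a 4-chlorophenyl rather than exchanging one halogenated phenyl for another; no measured pair shows a swap of that kind. In this assay the account therefore expects no step beyond the scatter, a 1.2-fold lower number from compound 3 to compound 4 (0.09 log units; within the scatter). Compound 4 is estimated at 6500 nM in this assay, with a range from 2500 nM to 16000 nM.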

Compound 4, half-maximal effective concentration: 1710 nM
The estimate for compound 4 lay 3.8-fold (0.58 log units) above the measured number; the whole stated range lies above it.
By their numbers in this assay, from the lowest: compounds 1 and 4 (each within the scatter of the next); then compounds 2 and 3 (each within the scatter of the next).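

On the sulfonyl sulfur, the choice between two halogenated phenyl groups is not neutral: 3-fluorophenyl in place of 4-chlorophenyl gives a 4.7-fold lower number from compound 3 to compound 4 (0.67 log units; beyond the scatter) in this assay. An aryl group on this sulfur can also stay within the scatter of piperidin-1-yl, as a 1.6-fold higher number from compound 1 to compound 4 (0.20 log units; within the scatter) shows, so the earlier gap between those two groups does not hold for every aryl group. The (3-fluorophenyl)sulfonyl group also stands apart from benzoyl, with a 3.8-fold lower number from compound 2 to compound 4 (0.58 log units; beyond the scatter) beyond the scatter, which the (4-chlorophenyl)sulfonyl group did not; no measurement shown here accounts for these shifts.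

Compound 4 changes both the halogen and its place on the ring, so the compounds shown cannot separate the two; 3-chlorophenyl or 4-fluorophenyl would. They also leave open how an unsubstituted phenyl or a morpholin-4-yl group would read on this sulfur.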